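Bromo for Chloro at a Second Position on the Benzyl Ring

The compounds below may be only part of what the source reports. "The series", "measured", "known", "first", "only" and "open" are said of these compounds alone.

Compound 1 `Clc1ccccc1CSc1nnc(-c2cnccn2)o1` and compound 2 `Brc1ccccc1CSc1nnc(-c2cnccn2)o1` share one core and differ only in bromo in place of chloro on an aromatic carbon. In a functional assay on SW 1116 cells (Homo sapiens) for antiproliferative activity, read by MTT assay, with a stated time of 48 h (on this read-out lower numbers stand for stronger inhibition and higher numbers for weaker inhibition), compound 1 gives 15100 nM, while compound 2 gives 2460 nM; the step is a 6.1-fold lower number from compound 1 to compound 2 (0.79 log units; beyond the scatter). Compound 3 `Clc1ccc(CSc2nnc(-c3cnccn3)n2-c2ccccc2)cc1` is built on a different core, and the difference between the two cores is not broken down here. In this assay compound 3 gives 12500 nM. Compound 4 `Brc1ccc(CSc2nnc(-c3cnccn3)n2-c2ccccc2)cc1` has not yet been measured; it differs from compound 3 by bromo in place of chloro on an aromatic carbon. The halogen sits ortho to a large group in compound 2 but para to a large group in compound 4, so this is the same kind of change, not the same one. Resting on a single precedent at a different place, compound 4 is expected to move by a 2.8-fold lower number from compound 3 to compound 4 (0.44 log units; beyond the scatter), a smaller step than that from compound 1 to compound 2. The estimate for compound 4 is 4500 nM.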

Compound 4, half-maximal inhibitory concentration: 6210 nM
For compound 4 the middle estimate is 1.4-fold (0.14 log units) below the measured one; the measured number falls inside the stated range.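

On the second core, the exchange of chloro for bromo gives a 2.0-fold lower number from compound 3 to compound 4 (0.30 log units; within the scatter) in this assay, so no firm change can be claimed for this pair. The step seen on the core of compound 1 therefore does not carry over at the same size to the core of compound 3: the same change on two cores in this assay, a 6.1-fold lower number (0.79 log units; beyond the scatter) from compound 1 to compound 2 and a 2.0-fold lower number (0.30 log units; within the scatter) from compound 3 to compound 4, 3.0-fold (0.48 log units) apart, beyond the scatter of two such steps. The halogen's place on the benzyl ring differs between the two pairs as well as the core, so these pairs do not show which difference accounts for the gap, and two pairs set no rule for the series.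

The compounds shown leave open how a fluoro or methoxy group would read in place of the halogen. They also leave open whether the exchange would behave the same way with a methyl group in place of the phenyl on the core of compound 3.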